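Working notes: the arm of compound 3 becomes compound 4

The source may report more compounds than this note shows. Statements on the series, on what has been measured and on what is new or still open speak of the compounds shown alone.

The compounds share one core bearing an ether-linked amide arm, and the arm is what changes. Compound 1 `O=C1NC2CSC(CCCCC(=O)N3CCN(C(=O)COC4=CC(=O)c5ccccc5C4=O)CC3)C2N1` gives 1500 nM in a functional assay on K562 cells (Homo sapiens) for antiproliferative activity; on this read-out higher numbers stand for weaker inhibition and lower numbers for stronger inhibition. Compound 2 `CC(C)(C)OC(=O)N1CCN(C(=O)COC2=CC(=O)c3c(O)cccc3C2=O)CC1` gives 1200 nM in this assay; the two values lie within the usual scatter of each other, so no order between compound 1 and compound 2 can be read from them. Compound 3 `O=C(O)CCCCCNC(=O)COC1=CC(=O)c2c(O)cccc2C1=O`, whose arm ends in a carboxy group, has no single number in this assay; its entry reads "not determined" (no result reported), so compound 3 serves only as a structural starting point here.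

Compound 4 `CC(C)(C)OC(=O)NCCCCCCNC(=O)COC1=CC(=O)c2c(O)cccc2C1=O` has not yet been measured in this assay. The change from compound 3 is ((tert-butoxycarbonyl)amino)methyl in place of carboxy on a saturated chain carbon, five bonds along the chain from an amide-type nitrogen. Among the compounds with values here, no step between two measured compounds resembles this exchange, so nothing measured anchors its size or direction. What can be said is that compound 2 also carries a tert-butoxycarbonyl group on its arm and gives 1200 nM in this assay. On that basis the arrival of compound 4 is expected to land near the values of compound 1 and compound 2, with no step beyond the scatter expected relative to compound 2. Compound 4 is estimated at 1500 nM in this assay, within a range from 500 nM to 5000 nM.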

Compound 4, half-maximal inhibitory concentration: 1000 nM
Compound 4: the middle estimate sits 1.5-fold (0.18 log units) above what was measured, within the range that was stated.
By their numbers in this assay, from the lowest: compounds 4, 2 and 1 (each within the scatter of the next).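

No new step can be read: compound 3 has no single number in this assay, so compound 4 cannot be compared with it. No measured evidence bears on this result. The compounds shown leave open the size and direction of exchanging carboxy for ((tert-butoxycarbonyl)amino)methyl on this arm in this assay.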